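A few compounds are considered here, and "the series" means these few. Any claim that something is new, unique, unknown or untested is made for them only; others in the source may bear on it.

Measured compounds:

Compound 1, `CN1C(=O)N(C)C2C1NC(=S)N2/N=C/C=C/c1ccccc1`: 46000 nM
Compound 2, `CN1C(=O)N(C)C2C1NC(=S)N2/N=C/C=C/c1ccccc1[N+](=O)[O-]`: 32400 nM
Compound 3, `CCN1C(=O)N(CC)C2C1NC(=S)N2/N=C/C=C/c1ccccc1`: 2250 nM

All three were tested in a functional assay on RD cells (Homo sapiens) for inhibition, read by MTT assay, with a stated time of 72 h; on this read-out higher numbers stand for weaker inhibition and lower numbers for stronger inhibition. Compound 1 gives 46000 nM, and compound 2 gives 32400 nM. The two differ in one place, (nitro in place of hydrogen on an aromatic carbon), and that change made a step of a 1.4-fold lower number from compound 1 to compound 2 (0.15 log units; within the scatter), so the two numbers cannot be told apart with confidence. Compound 3 carries a different core; how its core differs from that of compound 1 is not broken down here. In this assay compound 3 gives 2250 nM, the lowest of the three numbers, and its distance from both compound 1 and compound 2 lies beyond the scatter.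

Compound 4, `CCN1C(=O)N(CC)C2C1NC(=S)N2/N=C/C=C/c1ccccc1[N+](=O)[O-]`, has not yet been measured. It is built from compound 3 by the same change that turns compound 1 into compound 2: nitro in place of hydrogen on an aromatic carbon. The place is described in the same words for both pairs, so this is the same change on a different core. The only precedent, the step from compound 1 to compound 2, stayed within the scatter, and nothing among these compounds shows that the core of compound 3 answers this change differently. The step from compound 3 to compound 4 is therefore expected to be small, about a 1.3-fold lower number from compound 3 to compound 4 (0.10 log units; within the scatter), because the earlier step was a 1.4-fold lower number from compound 1 to compound 2 (0.15 log units; within the scatter). Compound 4 is estimated to give about 1800 nM in this assay, plausibly anywhere from 700 nM to 5000 nM.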

Compound 4, half-maximal inhibitory concentration: 15300 nM
The estimate for compound 4 lay 8.5-fold (0.93 log units) below the measured number; the measured number lies above the stated range.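

In this assay, putting nitro in place of hydrogen on an aromatic carbon gave a 6.8-fold higher number from compound 3 to compound 4 (0.83 log units; beyond the scatter), so on this core the change moved the number towards weaker inhibition. Set beside the earlier step, the same change did not carry over unchanged from one core to the other: the same change on two cores in this assay, a 1.4-fold lower number (0.15 log units; within the scatter) from compound 1 to compound 2 and a 6.8-fold higher number (0.83 log units; beyond the scatter) from compound 3 to compound 4, 9.7-fold (0.98 log units) apart, beyond the scatter of two such steps. In this series, then, the small result on the core of compound 1 is not a safe guide to the result on the core of compound 3, but two pairs cannot show why the cores answer differently or predict how the change would behave on any further core.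

The compounds shown have only hydrogen or nitro at this place on the aromatic ring, which leaves open whether a different group there, such as an amine or a carboxylic acid, would also give different steps on the two cores. They also leave open whether a longer chain on the core would keep the response seen from compound 3 to compound 4 or shift it again.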